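The compounds below may be only part of what the source reports. "The series", "measured", "known", "first", "only" and "open" are said of these compounds alone.

Compound 1 `CCCc1cc(CNC(=O)c2cc3nc(C)c([C@H](OC(C)(C)C)C(=O)O)c(-c4cc(F)c5c(c4C)CCCO5)n3n2)ccc1F` is the starting point of this step. In an ADME assay on MT2 cells (Homo sapiens) for cytotoxicity (a lower number here means that less compound is tolerated, a higher number that more compound is tolerated), compound 1 gives > 20000 nM, which is a limit of the assay rather than a number. Compound 2 `COc1cc(CNC(=O)c2cc3nc(C)c([C@H](OC(C)(C)C)C(=O)O)c(-c4cc(F)c5c(c4C)CCCO5)n3n2)ccc1F` carries methoxy in place of propyl on an aromatic carbon. In this assay compound 2 gives > 20000 nM, again a limit. Compound 3 `Cc1nc2cc(C(=O)NCc3ccc(F)cc3S(C)(=O)=O)nn2c(-c2cc(F)c3c(c2C)CCCO3)c1[C@H](OC(C)(C)C)C(=O)O` carries 4-fluoro-2-(methylsulfonyl)phenyl on the saturated chain carbon bound to the amide-type nitrogen. In this assay compound 3 gives > 40000 nM, also a limit. The step that the two limits leave unreadable from compound 1 to compound 2 and the step that the two limits leave unreadable from compound 1 to compound 3 are thus of unknown size, and the same holds for a step that the two limits leave unreadable from compound 2 to compound 3, since every value shown sits at the limit of > 20000 nM in this assay, at which 2 of the 3 values shown sit, or at the limit of > 40000 nM in this assay, at which 1 of the 3 values shown sits. Compound 4 `CNC(=O)c1cc(F)ccc1CNC(=O)c1cc2nc(C)c([C@H](OC(C)(C)C)C(=O)O)c(-c3cc(F)c4c(c3C)CCCO4)n2n1` has not yet been measured in this assay. It differs from compound 1 by 4-fluoro-2-(methylcarbamoyl)phenyl in place of 4-fluoro-3-propylphenyl on a saturated chain carbon bound to an amide-type nitrogen. Among the measured compounds shown here, the steps that bear on this change, from compound 1 to compound 3 and from compound 2 to compound 3, both exchange the group on the saturated chain carbon bound to the amide-type nitrogen and leave the tolerated concentration at a limit, so no step beyond the scatter is expected in this assay. Compound 4 is therefore expected to give 30000 nM, between 15000 nM and 60000 nM. The expected step is a step that the limit leaves unreadable from compound 1 to compound 4, most likely reported again as a limit.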

Compound 4, half-maximal cytotoxic concentration: > 40000 nM
Compound 4 gave a limit, no number; the forecaster's own chance of this, stated with the estimate: 85%; at least 1.3-fold (0.12 log units) between middle value and limit.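

In this assay compound 4 gives > 40000 nM, which is a limit of the assay. Among the compounds shown here, no step from compound 1, compound 2 or compound 3 to compound 4 can therefore be read. The compounds shown leave open where the actual half-maximal cytotoxic concentrations of these four compounds lie, and whether the exchanged groups make any difference in this assay.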